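The source may report more compounds than this note shows. Statements on the series, on what has been measured and on what is new or still open speak of the compounds shown alone.

Working notes on the series

The shared core carries a benzamide-type group on the amide nitrogen; the compounds differ in the ring on the carbonyl carbon. Compound 1 `COc1ccc(S(=O)(=O)Oc2ccccc2NC(=O)c2ccc(F)cc2)cc1` gives 89 nM in a functional assay on HCT-15 cells (Homo sapiens) for antiproliferative activity; on this read-out higher numbers stand for weaker inhibition and lower numbers for stronger inhibition. Compound 2 `COc1ccc(S(=O)(=O)Oc2ccccc2NC(=O)c2ccccc2)cc1` gives 310 nM, and the change from hydrogen in place of fluoro on an aromatic carbon reads as a 3.5-fold higher number from compound 1 to compound 2 (0.54 log units; beyond the scatter). Compound 3 `COc1ccc(S(=O)(=O)Oc2ccccc2NC(=O)c2ccc3ncccc3c2)cc1` reaches only the limit of the assay, > 10000 nM; this is a limit, not a number, and in this set it is the limit of > 10000 nM in this assay, at which 1 of the 3 values shown sits. Both steps into compound 3 are large: an at least 110-fold higher number from compound 1 to compound 3 (2.05 log units; beyond the scatter) and an at least 32-fold higher number from compound 2 to compound 3 (1.50 log units; beyond the scatter), so compound 3 stands at the weak end of the three.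

Compound 4 `COc1ccc(S(=O)(=O)Oc2ccccc2NC(=O)c2ccccn2)cc1` is not yet measured. It differs from compound 3 by pyridin-2-yl in place of quinolin-6-yl on a carbonyl carbon. For the measured compounds named here, the steps that bear on it are the two into compound 3, which show that quinolin-6-yl on the carbonyl carbon costs a large amount against phenyl or 4-fluorophenyl. Pyridin-2-yl is a single six-membered aromatic ring with one hetero atom, and no measured pair shows how it compares with phenyl on this carbon. The expectation is a large step toward stronger inhibition, an at least 10-fold lower number from compound 3 to compound 4 (1.00 log units; beyond the scatter), with wide uncertainty. For compound 4 the estimated value is 1000 nM, expected between 200 nM and 8000 nM.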

Compound 4, half-maximal inhibitory concentration: 110 nM
Compound 4: the middle estimate sits 9.1-fold (0.96 log units) above what was measured; the whole stated range lies above it.
By their numbers in this assay, from the lowest: compounds 1 and 4 (each within the scatter of the next); then compound 2. At a limit, above all of these: compound 3.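

Working from the pyridin-2-yl result on the carbonyl carbon, a ring with one hetero atom is not by itself tied to the weak end of the series, since the step from the quinolin-6-yl group is large: an at least 90-fold lower number from compound 3 to compound 4 (1.95 log units; beyond the scatter). Against phenyl the same ring gives the first measured gain from a ring nitrogen on this carbon, a 2.8-fold lower number from compound 2 to compound 4 (0.45 log units; beyond the scatter), while against 4-fluorophenyl there is a 1.2-fold higher number from compound 1 to compound 4 (0.09 log units; within the scatter), so in this assay pyridin-2-yl and 4-fluorophenyl cannot be told apart. The value of compound 3 remains a limit and not a number, so the size of its steps stays open-ended: the limit of > 10000 nM in this assay, at which 1 of the 4 values shown sits.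

A naphthalen-2-yl group on the carbonyl carbon would test whether the carbon-only second ring of quinolin-6-yl goes with the loss, and pyridin-3-yl would test whether the place of the ring nitrogen matters for the gain over phenyl. Also open, on these data alone, is whether a fluoro on the pyridin-2-yl ring would shift the number as it does on phenyl, where removing it gives a 3.5-fold higher number from compound 1 to compound 2 (0.54 log units; beyond the scatter).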